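Moving the chlorine on the weakest of three compounds

The source may report more compounds than this note shows. Statements on the series, on what has been measured and on what is new or still open speak of the compounds shown alone.

In a functional assay on HCT-116 cells (Homo sapiens) for antiproliferative activity, read by MTT assay, with a stated time of 72 h (on this read-out lower numbers stand for stronger inhibition and higher numbers for weaker inhibition), compound 1 (`O=C(CSc1ccc(Cl)cc1)Nc1ccc2nc(NC(=O)c3ccc(F)cc3)sc2c1`) gives 1360 nM and compound 2 (`O=C(CSc1ncccn1)Nc1ccc2nc(NC(=O)c3ccc(C(F)(F)F)cc3)sc2c1`) gives 2220 nM in the same read-out, two values within the usual scatter of each other. Compound 3 (`Cn1c(CNC(=O)c2cccs2)nnc1SCC(=O)Nc1ccc(Cl)cc1`) gives 91400 nM there, the highest number of the three, and its gap to each of the others lies beyond the scatter.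

Compound 4 (`Cn1c(CNC(=O)c2cccs2)nnc1SCC(=O)Nc1cccc(Cl)c1`) holds the same atoms as compound 3, joined differently (3-chlorophenyl in place of 4-chlorophenyl on an amide-type nitrogen): 3-chlorophenyl in place of 4-chlorophenyl on an amide-type nitrogen. Among the measured compounds shown here, no two measured compounds differ in one place only, so the data hold no direct guide to such a step in this assay and its size must be judged from the change alone. Nothing counted in the two groups differs, so no step beyond the scatter is expected, with a slight lean towards a lower number because compound 3 with 91400 nM stands at the top of the three. The estimated move (a 1.3-fold lower number from compound 3 to compound 4 (0.12 log units; within the scatter)) is expected to stay within the scatter. Compound 4 is expected at 70000 nM with an estimated range from 30000 nM to 150000 nM when it is measured.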

Compound 4, half-maximal inhibitory concentration: > 100000 nM
Compound 4: a limit, no number; the forecaster's own chance of this, stated with the estimate: 15%; middle value at least 1.4-fold (0.15 log units) from the limit.
By their numbers in this assay, from the lowest: compounds 1 and 2 (each within the scatter of the next); then compound 3. At a limit, above all of these: compound 4.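

In this assay compound 4 gives > 100000 nM, which is a limit of the assay and not a number. The set's first change in one place only, 3-chlorophenyl in place of 4-chlorophenyl on an amide-type nitrogen, reads as an at least 1.0-fold higher number from compound 3 to compound 4 (0.03 log units; that floor lies within the scatter), so on this nitrogen the new placement of the chlorine brings no lower number in this read-out. Going by these compounds, this step has only a floor and its true size stays unknown, because the read-out ends at a limit: the limit of > 100000 nM in this assay, at which 1 of the 4 values shown sits.

The compounds shown leave open how far compound 4 lies beyond its limit, and so whether the move of the chlorine changes the number by more than the usual scatter or hardly at all. They also leave open whether any other group on this phenyl ring, such as a methoxy group, a carboxylic acid or an amine in place of the chlorine, would bring the number down from the level of compound 3, or whether a plain phenyl would give a similar reading.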